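Moving the sulfur within the thiophene on the ether

A few compounds are considered here, and "the series" means these few. Any claim that something is new, unique, unknown or untested is made for them only; others in the source may bear on it.

Compound 1 `Cc1nc2c(OCc3ccccc3)ccc(C)n2c1C`: in a functional assay on the whole organism with Rattus norvegicus as the target (on this read-out lower numbers stand for an effect already at smaller amounts and higher numbers for an effect only at larger amounts of compound), compound 1 gives 8 mg/kg.
Compound 2 `Cc1nc2c(OCc3ccccn3)cccn2c1N`: in this assay compound 2 gives 2.3 mg/kg.
Compound 3 `Cc1nc2c(OCc3cccs3)cccn2c1N`: in this assay compound 3 gives 5 mg/kg.

Among the measured compounds shown here, compound 3 stands second highest of the three numbers; compound 1 lies within the scatter of it, and the only step beyond the scatter is a 2.2-fold higher number from compound 2 to compound 3 (0.34 log units; beyond the scatter). Compound 4 `Cc1nc2c(OCc3ccsc3)cccn2c1N` differs from compound 3 by thiophen-3-yl in place of thiophen-2-yl on a saturated chain carbon bound to an oxygen on an aromatic ring. For the measured compounds named here, no measured step moves the sulfur within a thiophene ring; the one step at this place, a 2.2-fold higher number from compound 2 to compound 3 (0.34 log units; beyond the scatter), exchanges a different ring altogether, so it offers no direct guide. The expected step is therefore no change at the digits printed from compound 3 to compound 4 (within the scatter), not beyond the scatter. Compound 4 is estimated at 5 mg/kg in this assay, with a range from 2.5 mg/kg to 10 mg/kg.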

Compound 4, dose for half-maximal effect: 8.4 mg/kg
Beside the measured number, compound 4's estimate is 1.7-fold (0.23 log units) below it, and the stated range covers the measured number.
By their numbers in this assay, from the lowest: compound 2; then compounds 3, 1 and 4 (each within the scatter of the next).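

In this assay, moving the attachment from thiophen-2-yl to thiophen-3-yl, with the same atoms joined differently, gives a 1.7-fold higher number from compound 3 to compound 4 (0.23 log units; within the scatter), so this change does not separate the two thiophenes at this position. Compound 2, with pyridin-2-yl, now stands apart from both thiophenes, the new comparison being a 3.7-fold higher number from compound 2 to compound 4 (0.56 log units; beyond the scatter). Nothing available gives a reason for either step. Still open, going by these compounds, is whether the lower number belongs to pyridin-2-yl alone or would also appear with pyridin-3-yl or pyridin-4-yl on the same saturated chain carbon.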